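A Nitrophenyl for Fluorophenyl Swap, Made Twice

A few compounds are considered here, and "the series" means these few. Any claim that something is new, unique, unknown or untested is made for them only; others in the source may bear on it.

Compound 1 `O=C1/C(=C/c2ccccc2F)CN(S(=O)(=O)c2ccc(F)cc2)C/C1=C\c1ccccc1F` and compound 2 `O=C1/C(=C/c2cccc([N+](=O)[O-])c2)CN(S(=O)(=O)c2ccc(F)cc2)C/C1=C\c1ccccc1F` share one core and differ only by 3-nitrophenyl in place of 2-fluorophenyl on a double-bonded chain carbon bound to a double-bonded ring carbon. In a functional assay on HepG2 cells (Homo sapiens) for cytotoxicity, read by MTT assay, with a stated time of 24 h (a lower number here means a stronger inhibitor, a higher number a weaker inhibitor), compound 1 gives 7220 nM, and compound 2 gives 7040 nM. The step is a 1.0-fold lower number from compound 1 to compound 2 (0.01 log units; within the scatter), so the two numbers cannot be told apart.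

Compound 3 `COc1cc(/C=C2\CN(S(=O)(=O)c3ccc(NC(C)=O)cc3)C/C(=C\c3ccccc3F)C2=O)cc(OC)c1OC` is built on a different core; how its core differs from that of compound 1 is not broken down here. In this assay compound 3 gives 4750 nM, which sits within the scatter of compound 1 and of compound 2.

Compound 4 `COc1cc(/C=C2\CN(S(=O)(=O)c3ccc(NC(C)=O)cc3)C/C(=C\c3cccc([N+](=O)[O-])c3)C2=O)cc(OC)c1OC` is not yet measured. Going by the values given here, it comes from compound 3 by 3-nitrophenyl in place of 2-fluorophenyl on a double-bonded chain carbon bound to a double-bonded ring carbon, the same change as the one from compound 1 to compound 2, at the same place. A step of similar size is expected here, a 1.0-fold higher number from compound 3 to compound 4 (0.00 log units; within the scatter), because the earlier one was a 1.0-fold lower number from compound 1 to compound 2 (0.01 log units; within the scatter). Compound 4 is therefore expected to give 4800 nM. For compound 4 the estimated range runs from 2400 nM to 9600 nM.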

Compound 4, half-maximal inhibitory concentration: 3340 nM
Estimate against measurement, compound 4: 1.4-fold (0.16 log units) above, and the stated range covers the measured number.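

In this assay, putting 3-nitrophenyl in place of 2-fluorophenyl on the second core gives a 1.4-fold lower number from compound 3 to compound 4 (0.15 log units; within the scatter), so this step, like the earlier one, cannot be told apart from no change at all. Set side by side, the two steps do not differ: the same change on two cores in this assay, a 1.0-fold lower number (0.01 log units; within the scatter) from compound 1 to compound 2 and a 1.4-fold lower number (0.15 log units; within the scatter) from compound 3 to compound 4, 1.4-fold (0.14 log units) apart, within the scatter of two such steps. This shows that on these two cores the swap behaves alike and leaves the number inside the usual noise, but it does not show that the swap has any real effect in either case, and two pairs say nothing about how it would behave on a third core.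

Going by these compounds, both steps exchange the same two groups at the same place, so it remains open whether a different group there, such as an amine or a carboxylic acid, would move the number beyond the scatter. If one did, it also remains open whether that larger step would carry from one core to the other, a test that two steps this small cannot provide.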